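Swapping a Halogen: From Fluoro to Bromo

The compounds below may be only part of what the source reports. "The series", "measured", "known", "first", "only" and "open" are said of these compounds alone.

Measured compounds:
- Compound 1, `Cc1n[nH]c2ccc(-c3nc4cnc(N5CCN(C)CC5)cn4c3Nc3cccc(F)c3)cc12`: 5.41%
- Compound 2, `Cc1n[nH]c2ccc(-c3nc4cnc(N5CCN(C)CC5)cn4c3Nc3ccc(F)cc3)cc12`: "not determined" (no result reported)
- Compound 3, `Cc1n[nH]c2ccc(-c3nc4cnc(N5CCN(C)CC5)cn4c3Nc3ccccc3Cl)cc12`: "not determined" (no result reported)

Three compounds share one core and differ only in the aromatic ring that hangs from the amino group. In a functional assay on CWR22R cells (Homo sapiens) for inhibition, with a stated time of 120 h, tested at 10 uM (on this read-out higher numbers stand for more inhibition at the one concentration tested (going by the name of the read-out) and lower numbers for less inhibition), compound 1 gives 5.41%, a small effect at the single concentration tested. In this assay, as far as these compounds go, compound 2 gives "not determined" (no result reported) and compound 3 gives "not determined" (no result reported), so compound 2 stands nowhere on the scale: its own inhibition is unknown, and the only reference point among its relatives is the low figure of compound 1.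

Compound 4, `Cc1n[nH]c2ccc(-c3nc4cnc(N5CCN(C)CC5)cn4c3Nc3ccc(Br)cc3)cc12`, is made from compound 2 by one change: bromo in place of fluoro on an aromatic carbon. Bromo enters where fluoro leaves, on an aromatic carbon of a six-membered aromatic ring of carbon only, para to a large group.

Among the measured compounds shown here, no step between measured compounds is available to gauge this swap. For this assay the step is expected to be small, without a clear direction, and within the usual scatter. Compound 4 is therefore estimated to give 8%, with a range from 0% to 30%.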

Compound 4, a percentage reported as inhibition, at one concentration (the size of the read-out at that concentration, not a potency): 11.7%
Compound 4: the middle estimate sits 3.7 percentage points below what was measured; low and high end bracket the measured number.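

Among the compounds shown here, compound 4 gives the series a second number, and the only step it allows is a double change: 4-bromophenyl in place of 3-fluorophenyl, read in this assay as a number 6.3 percentage points higher from compound 1 to compound 4 (within the scatter). Changing both the halogen and where it sits on the ring therefore leaves no difference that can be told from the scatter of repeat measurements, while the direct fluoro-to-bromo step from compound 2 cannot be read, as compound 2 has no result. No measured property speaks to why the two readings lie so close.

As far as these compounds go, whether an amine or a carboxylic acid in place of bromo would give a clearly larger inhibition remains open. So does how compound 2 and compound 3 would read on this scale.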